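The source may report more compounds than this note shows. Statements on the series, on what has been measured and on what is new or still open speak of the compounds shown alone.

In a functional assay on HeLa cells (Homo sapiens) for cytotoxicity, read by sulforhodamine B assay, with a stated time of 72 h (on this read-out lower numbers stand for stronger inhibition and higher numbers for weaker inhibition), compound 1 `C=C1C(=O)O[C@@H]2CC(C)=C([C@@H](C)CCCOC(C)=O)[C@@H](OC(=O)CN3CCCC3)[C@H]12` gives 12700 nM. Compound 3 `C=C1C(=O)O[C@@H]2CC(C)=C([C@@H](C)CCCOC(C)=O)[C@@H](OC(=O)c3ccccc3F)[C@H]12` gives 17000 nM, and the comparison reads a 1.3-fold higher number from compound 1 to compound 3 (0.13 log units; within the scatter), so these two stand level. Compound 2 `C=C1C(=O)O[C@@H]2CC(C)=C([C@@H](C)CCCOC(C)=O)[C@@H](OC(=O)COc3cccc(C(C)=O)c3)[C@H]12` gives 38600 nM, and that comparison reads a 3.0-fold higher number from compound 1 to compound 2 (0.48 log units; beyond the scatter). Compound 1 therefore shares the stronger end of this small set with compound 3.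

Compound 4 `C=C1C(=O)O[C@@H]2CC(C)=C([C@@H](C)CCCOC(C)=O)[C@@H](OC(=O)c3cccc(F)c3)[C@H]12` has not been measured. Its difference from compound 1 is 3-fluorophenyl in place of (pyrrolidin-1-yl)methyl on a carbonyl carbon, with 3-fluorophenyl in place of (pyrrolidin-1-yl)methyl on a carbonyl carbon. The closest evidence is the step to compound 3, which carries 2-fluorophenyl on that same carbonyl carbon: a 1.3-fold higher number from compound 1 to compound 3 (0.13 log units; within the scatter). A second step, a 2.3-fold lower number from compound 2 to compound 3 (0.36 log units; beyond the scatter), shows that compound 3 also differs from compound 2. Among the measured compounds shown here, no measured pair compares 2-fluorophenyl with 3-fluorophenyl directly, so the uncertainty stays wide.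

No change beyond the scatter is expected, and the estimated step is a 1.3-fold higher number from compound 1 to compound 4 (0.10 log units; within the scatter). The estimate for compound 4 is 16000 nM, with an expected range from 7500 nM to 34000 nM.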

Compound 4, half-maximal inhibitory concentration: 11800 nM
Beside the measured number, compound 4's estimate is 1.4-fold (0.13 log units) above it; low and high end bracket the measured number.
By their numbers in this assay, from the lowest: compounds 4, 1 and 3 (each within the scatter of the next); then compound 2.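

In this assay, among the compounds shown here, this is the first direct comparison of 2-fluorophenyl and 3-fluorophenyl on this carbonyl carbon, and the swap stays within the scatter (a 1.4-fold lower number from compound 3 to compound 4 (0.16 log units; within the scatter)). Replacing the (pyrrolidin-1-yl)methyl group, whose ring holds a nitrogen, with the all-carbon aromatic ring of 3-fluorophenyl also leaves the two compounds level (a 1.1-fold lower number from compound 1 to compound 4 (0.03 log units; within the scatter)), so these three groups cannot be told apart here. The (3-acetylphenoxy)methyl group of compound 2 goes against this flat picture, since the step to 3-fluorophenyl lies beyond the scatter (a 3.3-fold lower number from compound 2 to compound 4 (0.51 log units; beyond the scatter)).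

Nothing shown gives a reason for these results. Still open, going by these compounds, is whether 4-fluorophenyl, an unsubstituted phenyl or a carboxylic acid on this carbonyl carbon would also stay level with compound 1.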